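Trimming the imine substituent: an expected shift in cytotoxicity

The source may hold more compounds than are shown below. What is called first, only, known or untested is meant among the compounds shown, and "the series" means these compounds.

Of the compounds shown here, two have been tested. Compound 1 `N#CC1=C(NC(=O)c2ccc([N+](=O)[O-])cc2)N(c2ccc(S(N)(=O)=O)cc2)C2=C(C(=O)CCC2)C1c1ccc(Cl)cc1Cl` carries an amide on the shared core, and in a functional assay on Ehrlich cells (Mus musculus) for cytotoxicity, read by trypan blue exclusion, with a stated time of 2 h, tested at 50 ug/mL (a lower number here means a weaker effect, a higher number a stronger effect of the compound at the concentration tested), compound 1 gives 50%. Compound 2 `CN(C)c1ccc(/C=C/C=N/C2=C(C#N)C(c3ccc(Cl)cc3Cl)C3=C(CCCC3=O)N2c2ccc(S(N)(=O)=O)cc2)cc1` bears an imine instead, and in this assay compound 2 gives 20%, the lower of the two numbers and beyond the scatter from compound 1. Compound 3 `CCO/C=N/C1=C(C#N)C(c2ccc(Cl)cc2Cl)C2=C(CCCC2=O)N1c1ccc(S(N)(=O)=O)cc1` has not been measured; it differs from compound 2 in one place: ethoxy in place of 2-(4-(dimethylamino)phenyl)ethenyl on a carbon with a double bond to nitrogen. Within the data shown here, no step between measured compounds shows what this change does. Among the measured compounds shown here, the only pointer is that compound 2, with its larger substituent, gives 20%, whereas compound 1 gives 50%, so a modest rise is expected, though it may stay within the scatter. The expected step is a number 10 percentage points higher from compound 2 to compound 3 (within the scatter). Compound 3 is estimated at about 30%, within a range of 10% to 55%.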

Compound 3, a percentage reported as activity, at one concentration (the size of the read-out at that concentration, not a potency): 35%
The estimate for compound 3 lay 5 percentage points below the measured number; measured number inside the range.
By their numbers in this assay, from the lowest: compound 2; then compound 3; then compound 1.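

The place on the carbon with a double bond to nitrogen now has a measured step: in this assay, ethoxy in place of 2-(4-(dimethylamino)phenyl)ethenyl gives a number 15 percentage points higher from compound 2 to compound 3 (beyond the scatter), so the read-out responds to what this position carries. Exchanging the whole amide group for the ethoxy imine group on the double-bonded ring carbon gives a number 15 percentage points lower from compound 1 to compound 3 (beyond the scatter), which places the ethoxy imine apart from the amide as well as from the larger imine. Nothing available accounts for either step.

On these data alone, with only two imine substituents, it remains open whether the rise tracks the size of the group or is particular to ethoxy. As far as these compounds go, how a methoxy group, a longer chain such as butoxy, or an amine would read in this same place also remains open.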